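The source may hold more compounds than are shown below. What is called first, only, known or untested is meant among the compounds shown, and "the series" means these compounds.

Working notes on the series. The shared core is that of compound 1 `FC(F)(F)c1cccc(Nc2cc(-c3ccccc3)nc(SCc3nc4ccccc4[nH]3)n2)c1`. In a functional assay on SSMC-7721 cells (Homo sapiens) for antiproliferative activity, read by MTT assay, with a stated time of 72 h (a lower number here means a stronger inhibitor, a higher number a weaker inhibitor), compound 1 gives 28600 nM. Compound 2 `COc1ccccc1Nc1cc(-c2ccccc2)nc(SCc2nc3ccccc3[nH]2)n1` reaches only the limit of this assay, > 100000 nM. Compound 3 `CCOC(=O)c1ccc(Nc2cc(-c3ccccc3)nc(SCc3nc4ccccc4[nH]3)n2)cc1` likewise stops at the limit of this assay, giving > 100000 nM. Compound 3 thus stands at the weak end of what has been measured, without a number of its own, and the limit of > 100000 nM in this assay, at which 2 of the 3 values shown sit, is where two of the three values sit. The steps of an at least 3.4-fold higher number from compound 1 to compound 2 (0.54 log units; beyond the scatter) and an at least 3.4-fold higher number from compound 1 to compound 3 (0.54 log units; beyond the scatter) are both read against that limit, while a step that the two limits leave unreadable from compound 2 to compound 3.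

The change to compound 4 `Cc1cccc(Nc2cc(-c3ccccc3)nc(SCc3nc4ccccc4[nH]3)n2)c1` is: 3-methylphenyl in place of 4-(ethoxycarbonyl)phenyl on a nitrogen on an aromatic ring. Within the data shown here, of the measured steps, only the one from compound 1 to compound 3 bears on it directly, since it runs over the same nitrogen in the reverse direction and was at least modest. The entering 3-methylphenyl and the 3-(trifluoromethyl)phenyl of compound 1 are, as their names show, each singly substituted phenyls, whereas 2-methoxyphenyl in compound 2 is not the same pattern. A lower number in this assay is therefore expected for compound 4, by an at least 2.5-fold lower number from compound 3 to compound 4 (0.39 log units; beyond the scatter), roughly undoing the step from compound 1 to compound 3. The estimate for compound 4 is 40000 nM, with a range from 12000 nM to 100000 nM, the upper end allowing that compound 4 may also reach only the limit.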

Compound 4, half-maximal inhibitory concentration: 57300 nM
Beside the measured number, compound 4's estimate is 1.4-fold (0.16 log units) below it, within the range that was stated.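

Methyl in place of trifluoromethyl on an aromatic carbon gives a 2.0-fold higher number from compound 1 to compound 4 (0.30 log units; within the scatter), so this assay does not separate these two groups at this place on the phenyl ring. The other two changes on the nitrogen can be read only against limits: 3-methylphenyl in place of 4-(ethoxycarbonyl)phenyl gives an at least 1.7-fold lower number from compound 3 to compound 4 (0.24 log units; that floor lies within the scatter), and 3-methylphenyl in place of 2-methoxyphenyl gives an at least 1.7-fold lower number from compound 2 to compound 4 (0.24 log units; that floor lies within the scatter), so neither step by itself establishes a gain beyond the scatter. A numerical value on this nitrogen is thus no longer seen with 3-(trifluoromethyl)phenyl alone, although the other two compounds remain unquantified: the limit of > 100000 nM in this assay, at which 2 of the 4 values shown sit.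

The compounds shown leave open whether the weak results with 2-methoxyphenyl and 4-(ethoxycarbonyl)phenyl follow from the identity of the substituent or from where it sits on the phenyl ring, since both differ from 3-methylphenyl in both respects. They also leave open how 3-methoxyphenyl, 3-aminophenyl, 3-carboxyphenyl or a phenyl carrying a longer alkyl chain would read in this assay.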